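Swapping Nitro for Isopropyl in a Small Series

A few compounds are considered here, and "the series" means these few. Any claim that something is new, unique, unknown or untested is made for them only; others in the source may bear on it.

Compound 1 `CC(=O)/C=C/c1ccc([N+](=O)[O-])cc1` gives 2600 nM
Compound 2 `CC(=O)/C=C/c1ccc(F)c(Br)c1` gives 2900 nM
Compound 3 `CC(=O)/C=C/c1ccc(OCc2ccccc2)c(OCc2ccccc2)c1` gives 8400 nM

In a functional assay on K562 cells (Homo sapiens) for inhibition (a higher number here means a weaker inhibitor, a lower number a stronger inhibitor), compound 1 at 2600 nM and compound 2 at 2900 nM lie within the scatter of each other, while compound 3 at 8400 nM has a number beyond the scatter above compound 1 in this series. The next compound is compound 4 `CC(=O)/C=C/c1ccc(C(C)C)cc1` and the change is isopropyl in place of nitro on an aromatic carbon which in words means isopropyl in place of nitro on an aromatic carbon. Going by the values given here, no two measured compounds differ in one place, so the data give no direct measure of this swap. In this assay a small step toward a higher number is expected, probably within the scatter, since even compound 3 reaches only 8400 nM among quite varied groups. The estimated step of a 1.5-fold higher number from compound 1 to compound 4 (0.19 log units; within the scatter) is modest. For compound 4 the estimated value is 4000 nM with an expected range of 1500 nM to 11000 nM in this assay.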

Compound 4, half-maximal inhibitory concentration: 21000 nM
Estimate against measurement, compound 4: 5.3-fold (0.72 log units) below; measured number above the stated range.
By their numbers in this assay, from the lowest: compounds 1 and 2 (each within the scatter of the next); then compound 3; then compound 4.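

In this assay, going by these compounds alone, isopropyl in place of nitro on an aromatic carbon gives an 8.1-fold higher number from compound 1 to compound 4 (0.91 log units; beyond the scatter), the first direct reading of a single change, and it shows that the group at this carbon matters. Nitro and isopropyl each hold 3 heavy atoms, so the heavy-atom count alone does not set the number here. No measurement shown explains the gap. The compounds shown leave open whether an amine or a carboxylic acid on this same carbon would give a number closer to compound 1 or to compound 4.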